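Replacing the methoxycarbonyl group of compound 1 with methyl

A few compounds are considered here, and "the series" means these few. Any claim that something is new, unique, unknown or untested is made for them only; others in the source may bear on it.

For the measured compounds named here, in a functional assay on MCF7 cells (Homo sapiens) for antiproliferative activity, with a stated time of 72 h (a higher number here means a weaker inhibitor, a lower number a stronger inhibitor), compound 1 (`COC(=O)CN(C)Cc1c(OC)cc(OC)c(C(=O)/C=C/c2ccccc2Cl)c1O`) gives 10600 nM, the lower of the two numbers known so far. Going by the values given here, the only other measured compound, compound 2 (`COc1cc(OC)c(C(=O)/C=C/c2ccccc2Cl)c(O)c1CN(C)CC(=O)O`), gives 73200 nM. Compound 3 (`CCN(C)Cc1c(OC)cc(OC)c(C(=O)/C=C/c2ccccc2Cl)c1O`) keeps the shared core but carries methyl in place of methoxycarbonyl on a saturated chain carbon bound to an amine nitrogen. Among the compounds with values here, one measured step bears on this, and only indirectly: a 6.9-fold higher number from compound 1 to compound 2 (0.84 log units; beyond the scatter), a modest step with hydrogen in place of methyl on an oxygen next to a carbonyl group. That step alters the group that leaves here, but it is a different change, so it offers only a rough scale. No step beyond the scatter is firmly expected in this assay, with a slight lean towards a lower number. The expected step is a 1.3-fold lower number from compound 1 to compound 3 (0.12 log units; within the scatter). Compound 3 is estimated at 8000 nM, with an expected range of 2500 nM to 25000 nM.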

Compound 3, half-maximal inhibitory concentration: 6800 nM
The estimate for compound 3 lay 1.2-fold (0.07 log units) above the measured number; the measured number falls inside the stated range.
By their numbers in this assay, from the lowest: compounds 3 and 1 (each within the scatter of the next); then compound 2.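

In this assay, the methoxycarbonyl group on this saturated chain carbon bound to an amine nitrogen can give way to methyl with no change beyond the scatter (a 1.6-fold lower number from compound 1 to compound 3 (0.19 log units; within the scatter)), so among these compounds the methoxycarbonyl group is not required for the antiproliferative activity seen. Methyl in place of carboxy at the same place gives a large step (an 11-fold lower number from compound 2 to compound 3 (1.03 log units; beyond the scatter)), which leaves compound 2, with its carboxy group, as the compound that stands apart from the other two. Nothing available explains either step.

The compounds shown leave open how a longer chain such as propyl, a hydroxyl group or a primary amide would behave at this place. They also leave open whether these steps would hold on a core carrying another group instead of the chlorine.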